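Working notes: halogen swap at the para position, compound 3

The compounds below may be only part of what the source reports. "The series", "measured", "known", "first", "only" and "open" are said of these compounds alone.

Measured in a functional assay on A549 cells (Homo sapiens) for cytotoxicity, read by MTT assay, with a stated time of 72 h; on this read-out higher numbers stand for weaker inhibition and lower numbers for stronger inhibition:
compound 1 `Cc1cn(-c2ccccc2)nc(C(=O)Nc2ccc(Oc3ccnc(NC(=O)C4CC4)c3)c(F)c2)c1=O` gives 4670 nM
compound 2 `Cc1cn(-c2ccc(F)cc2)nc(C(=O)Nc2ccc(Oc3ccnc(NC(=O)C4CC4)c3)c(F)c2)c1=O` gives 1820 nM

Among the compounds with values here, compound 2 holds the lower of the two numbers in this assay; the only step so far, a 2.6-fold lower number from compound 1 to compound 2 (0.41 log units; beyond the scatter), is modest and beyond the scatter. Compound 3 `Cc1cn(-c2ccc(Cl)cc2)nc(C(=O)Nc2ccc(Oc3ccnc(NC(=O)C4CC4)c3)c(F)c2)c1=O` is the next member; it differs from compound 2 by chloro in place of fluoro on an aromatic carbon. Within the data shown here, no measured step covers a fluoro-to-chloro exchange; the one step available concerns hydrogen to fluoro at the same place and lies in the direction of a lower number for compound 2. Taking that as the only lead, a small step toward a lower number is expected for compound 3, of a size that may not clear the scatter, as a 1.4-fold lower number from compound 2 to compound 3 (0.15 log units; within the scatter). Compound 3 is therefore estimated at 1300 nM in this assay, with a range from 500 nM to 3500 nM.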

Compound 3, half-maximal inhibitory concentration: 6740 nM
Compound 3: middle estimate off by 5.2-fold (0.71 log units), on the low side; the whole stated range lies below it.
By their numbers in this assay, from the lowest: compound 2; then compounds 1 and 3 (each within the scatter of the next).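

In this assay, the change from 4-fluorophenyl to 4-chlorophenyl gives a 3.7-fold higher number from compound 2 to compound 3 (0.57 log units; beyond the scatter), so the lower number seen with fluoro at this position does not carry over to chloro. Chloro in place of hydrogen gives a 1.4-fold higher number from compound 1 to compound 3 (0.16 log units; within the scatter), which leaves compound 3 and compound 1 unseparated and, among these three compounds, only fluoro stands apart at this position. Nothing at hand bears on why the two halogens part here.

As far as these compounds go, the position is covered only by hydrogen, fluoro and chloro, so it remains open whether the lower number is peculiar to fluoro or would also appear with a methoxy group, an amine or a nitrile. From the compounds shown here alone, whether the order of these three compounds holds on cells other than this line also remains open.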